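This account rests on a few compounds, and the source may have more. Where it says the series, first, only, none or still open, it means among the compounds named here.

In a functional assay on HBL-100 cells (Homo sapiens) for inhibition, read by sulforhodamine B assay, with a stated time of 48 h (on this read-out lower numbers stand for stronger inhibition of growth and higher numbers for weaker inhibition of growth), three compounds have been measured so far:

compound 1 `CC(=O)OC/C(=C\C1CCCCC1)C(=O)c1ccccc1` gives 21000 nM
compound 2 `CC(=O)OC/C(=C\c1ccccc1)C(=O)c1ccccc1` gives 17000 nM
compound 3 `CC(=O)OC/C(=C\c1ccccc1Br)C(=O)c1ccccc1` gives 22000 nM

Compound 1 holds the second highest of the three numbers. The nearest gap is a 1.0-fold higher number from compound 1 to compound 3 (0.02 log units; within the scatter) and the furthest is a 1.2-fold lower number from compound 1 to compound 2 (0.09 log units; within the scatter); all three values lie within the scatter of one another, so no order among them can be read.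

Compound 4 `CC(=O)OC/C(=C\C1CCCCC1)C(=O)c1ccc(Cl)cc1` has not yet been measured in this assay. It differs from compound 1 by chloro in place of hydrogen on an aromatic carbon. The site is an aromatic carbon of a six-membered aromatic ring of carbon only, para to a large group; cut one bond further out, the change reads phenyl to 4-chlorophenyl. The measured step that comes closest in kind is the exchange of hydrogen for a halogen on an aromatic carbon, a 1.3-fold higher number from compound 2 to compound 3 (0.11 log units; within the scatter), which stayed within the scatter, though it sat on the other ring. The remaining two steps replaced the whole group on the double-bonded chain carbon and likewise stayed within the scatter. On that basis compound 4 is expected to give a number close to that of compound 1, with no change at the digits printed from compound 1 to compound 4 (within the scatter) not beyond the scatter. Compound 4 is therefore estimated at 21000 nM, within a range from 9000 nM to 50000 nM.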

Compound 4, concentration for 50% growth inhibition: 31000 nM
For compound 4 the middle estimate is 1.5-fold (0.17 log units) below the measured one; the range from low to high includes it.
By their numbers in this assay, from the lowest: compounds 2, 1, 3 and 4 (each within the scatter of the next).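

In this assay, for the compounds shown here, the step of a 1.5-fold higher number from compound 1 to compound 4 (0.17 log units; within the scatter) gives the first reading at this place, an aromatic carbon of a six-membered aromatic ring of carbon only, para to a large group. Chloro in place of hydrogen here stays within the scatter, as did the earlier exchange of bromo for hydrogen on the other ring, a 1.3-fold higher number from compound 2 to compound 3 (0.11 log units; within the scatter), so in these two pairs a single halogen on either ring gives no step beyond the scatter. No measurement offered here explains the size of this step or links it to any property of the chloro group.

The compounds shown leave open whether a different group at this place, such as an amine, a carboxylic acid or a methoxy group, would give a step beyond the scatter. Since every step shown lies within the scatter, they also leave open whether any change to the shared core would do so, for instance a hydroxyl group or a longer ester chain in place of the acetoxy group.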